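The source may hold more compounds than are shown below. What is called first, only, known or untested is meant among the compounds shown, and "the series" means these compounds.

The measured compounds and their numbers in a functional assay on HeLa cells (Homo sapiens) for cytotoxicity, read by MTT assay, with a stated time of 48 h; on this read-out lower numbers stand for stronger inhibition and higher numbers for weaker inhibition:

Compound 1, `COc1cc(-c2cc(C(=O)Nc3nc4ccc(F)cc4s3)nc3cc(-c4ccccc4)nn23)cc(OC)c1OC`, gives 25100 nM.
Compound 2, `COc1ccc(-c2cc(C(=O)Nc3nc4ccccc4s3)nc3cc(-c4ccccc4)nn23)cc1`, gives 4670 nM.
Compound 3, `COc1ccc(-c2cc(C(=O)Nc3nc4ccccc4s3)nc3cc(-c4ccccc4)nn23)cc1OC`, gives 8910 nM.

Compound 3 stands second highest of the three. Its nearest neighbour is compound 2, and a 1.9-fold higher number from compound 2 to compound 3 (0.28 log units; within the scatter), so these two cannot be told apart; compound 1 gives a higher number than compound 3 by a margin that lies beyond the scatter.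

Compound 4 is `COc1ccc(-c2cc(C(=O)Nc3nc4cc(C)c(C)cc4s3)nc3cc(-c4ccccc4)nn23)cc1OC`. Its difference from compound 3 is 5,6-dimethyl-1,3-benzothiazol-2-yl in place of 1,3-benzothiazol-2-yl on an amide-type nitrogen. Within the data shown here, no measured step touches this part of the molecule: the one step at hand, from compound 2 to compound 3, alters the other aryl group and lies within the scatter, and compound 1 differs from compound 3 in two places at once. The change to the benzothiazole is therefore unanchored, and no step beyond the scatter is expected in either direction; the estimated step of a 1.1-fold lower number from compound 3 to compound 4 (0.05 log units; within the scatter) reflects this. Compound 4 is expected to give about 8000 nM in this assay, with a range from 3000 nM to 25000 nM.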

Compound 4, half-maximal inhibitory concentration: 6760 nM
The estimate for compound 4 lay 1.2-fold (0.07 log units) above the measured number; measured number inside the range.
By their numbers in this assay, from the lowest: compounds 2, 4 and 3 (each within the scatter of the next); then compound 1.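

Compound 4 gives the only view among these compounds of a single change on the group at the amide-type nitrogen: in this assay, 5,6-dimethyl-1,3-benzothiazol-2-yl in place of 1,3-benzothiazol-2-yl gives a 1.3-fold lower number from compound 3 to compound 4 (0.12 log units; within the scatter), so the two compounds cannot be told apart. At this place, then, the larger group is accepted with no change that this read-out can resolve. Nothing measured on these compounds bears on why this is so.

As far as these compounds go, it remains open whether an amine or a carboxylic acid in place of the methyl groups of 5,6-dimethyl-1,3-benzothiazol-2-yl would move the number beyond the scatter. From the compounds shown here alone, it is also open whether the same replacement would read alike on the core of compound 2.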